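A Methyl Group Added to a Flat Series

The source may report more compounds than this note shows. Statements on the series, on what has been measured and on what is new or still open speak of the compounds shown alone.

In a functional assay on KB cells (Homo sapiens) for inhibition, read by sulforhodamine B assay (a higher number here means a weaker inhibitor of growth, a lower number a stronger inhibitor of growth), compound 1 `c1ccc(-c2ccc(-c3ccc(-c4nc5ccccc5[nH]4)cc3)cc2)cc1` gives 39700 nM, level within the scatter with compound 2 `Oc1ccc(-c2ccc(-c3ccc(-c4nc5ccccc5[nH]4)cc3)cc2)cc1` at 41000 nM and compound 3 `COc1ccc(-c2ccc(-c3ccc(-c4nc5ccccc5[nH]4)cc3)cc2)cc1` at 47200 nM. Compound 4 `Cc1ccc2[nH]c(-c3ccc(-c4ccc(-c5ccccc5)cc4)cc3)nc2c1` differs from compound 1 by methyl in place of hydrogen on an aromatic carbon. Within the data shown here, three measured steps bear on this. Hydroxy in place of hydrogen gave a 1.0-fold higher number from compound 1 to compound 2 (0.01 log units; within the scatter), methoxy in place of hydrogen gave a 1.2-fold higher number from compound 1 to compound 3 (0.08 log units; within the scatter), and methyl in place of hydrogen on an oxygen gave a 1.2-fold higher number from compound 2 to compound 3 (0.06 log units; within the scatter). None of these changes the carbon altered in compound 4, so they guide only loosely. In this assay the expected result is a 1.0-fold higher number from compound 1 to compound 4 (0.00 log units; within the scatter), with no step beyond the scatter. Compound 4 is estimated at 40000 nM, within an expected range of 24000 nM to 65000 nM.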

Compound 4, concentration for 50% growth inhibition: 32100 nM
Compound 4: the middle estimate sits 1.2-fold (0.10 log units) above what was measured; low and high end bracket the measured number.
By their numbers in this assay, from the lowest: compounds 4, 1, 2 and 3 (each within the scatter of the next).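

In this assay, methyl in place of hydrogen on an aromatic carbon gave a 1.2-fold lower number from compound 1 to compound 4 (0.09 log units; within the scatter) and so did not move the number beyond the scatter. The earlier steps shown here changed a different carbon, whereas compound 4 shows that this carbon of the fused system of two rings also carries a methyl with no clear effect on growth inhibition. No measurement here explains this flat result.

Methyl is a single small test of this position. An amine, a carboxylic acid or a longer chain on the same carbon remains an open question.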